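One Group Exchanged on Compound 1

This account rests on a few compounds, and the source may have more. Where it says the series, first, only, none or still open, it means among the compounds named here.

Compound 1 `CCOC(=O)C1=C(NN=C(C(C)=O)C(C)=O)Nc2[nH]nc(C)c2C1c1ccc(N(C)C)cc1` gives 17000 nM in a functional assay on HeLa cells (Homo sapiens) for inhibition, read by MTT assay, with a stated time of 48 h (on this read-out higher numbers stand for weaker inhibition and lower numbers for stronger inhibition), as measured
Compound 2 `CCOC(=O)C1=C(N/N=C(\c2ccc([N+](=O)[O-])cc2)N2CCN(c3ccc(F)cc3)CC2)Nc2[nH]nc(C)c2C1c1ccc(N(C)C)cc1` gives 87000 nM in this assay as measured

Only these two compounds have been measured. Compound 1 holds the lower number of the two, and the gap to compound 2 lies beyond the usual scatter. Compound 3 `CCOC(=O)C1=C(N/N=C(\C#N)C(N)=O)Nc2[nH]nc(C)c2C1c1ccc(N(C)C)cc1` keeps the core of compound 1 and differs in a single group on an amine nitrogen, and the change is a group of 7 heavy atoms (3 carbon, 3 nitrogen, 1 oxygen; no ring) in place of a group of 8 heavy atoms (5 carbon, 1 nitrogen, 2 oxygen; no ring), on an amine nitrogen in full. Among the compounds with values here, no measured pair shows what an exchange of this kind does, so the expectation rests on compound 1 at 17000 nM as its anchor. In this assay, from the compounds shown here alone, no step beyond the scatter is expected, and the direction stays open. The expected size is an estimated 1.2-fold higher number from compound 1 to compound 3 (0.07 log units; within the scatter) and no more. Compound 3 is estimated at 20000 nM with an expected range from 7000 nM to 60000 nM in this reading.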

Compound 3, half-maximal inhibitory concentration: 47300 nM
Estimate against measurement, compound 3: 2.4-fold (0.37 log units) below; the range from low to high includes it.
By their numbers in this assay, from the lowest: compound 1; then compounds 3 and 2 (each within the scatter of the next).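

In this assay, the exchange on an amine nitrogen whose other neighbour is a double-bonded ring carbon gives a 2.8-fold higher number from compound 1 to compound 3 (0.44 log units; beyond the scatter) and so shows that, with the core of compound 1 kept, the number at this position responds to the group it carries. The step belongs to the exchange as a whole, in which a group with a triple bond and a hydrogen-bond donor replaces one with neither. Nothing measured here explains the step.

Within the data shown here, the single pair cannot separate the part played by the nitrile from that of the amide hydrogen. From the compounds shown here alone, how a carboxylic acid, a primary amine or a simple ethyl chain would read on this amine nitrogen remains open.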